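The source may report more compounds than this note shows. Statements on the series, on what has been measured and on what is new or still open speak of the compounds shown alone.

Compound 3 `O=C(NO)c1ccc(NCc2nc(-c3ccccc3)nn2-c2ccccc2)cc1` gives 112 nM in an assay on Sf9 cells for inhibition of protein deacetylase HDAC6 (Homo sapiens), read by fluorescence, with a stated time of 40 min (a higher number here means a weaker inhibitor, a lower number a stronger inhibitor), the lowest of the three numbers, although compound 1 `O=C(NO)c1ccc(NCc2nc(-c3cccc(Cl)c3)nn2-c2ccccc2)cc1` at 115 nM lies within the scatter of it; compound 2 `O=C(NO)c1ccc(NCc2nc(-c3cc4ccccc4s3)nn2-c2ccccc2)cc1` gives 324 nM. Compound 4 `O=C(NO)c1ccc(NCc2nc(-c3ccccc3Cl)nn2-c2ccccc2)cc1` differs from compound 3 by chloro in place of hydrogen on an aromatic carbon, placed on an aromatic carbon of a six-membered aromatic ring of carbon only, ortho to a large group. The step that bears on this is a 1.0-fold lower number from compound 1 to compound 3 (0.01 log units; within the scatter), where a chloro left that ring with no change beyond the scatter; the steps of a 2.8-fold higher number from compound 1 to compound 2 (0.45 log units; beyond the scatter) and a 2.9-fold lower number from compound 2 to compound 3 (0.46 log units; beyond the scatter) concern a different group and do not speak to it. Accordingly the expectation is a 1.1-fold higher number from compound 3 to compound 4 (0.03 log units; within the scatter), nothing beyond the scatter. Compound 4 is estimated at 120 nM in this assay, with a range from 55 nM to 260 nM.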

Compound 4, half-maximal inhibitory concentration: 185 nM
Compound 4: middle estimate off by 1.5-fold (0.19 log units), on the low side; the range from low to high includes it.
By their numbers in this assay, from the lowest: compounds 3, 1, 4 and 2 (each within the scatter of the next, the first and the last beyond it).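

Chloro ortho to a large group gives a 1.7-fold higher number from compound 3 to compound 4 (0.22 log units; within the scatter) in this assay, so this position takes the atom with no change beyond the scatter. Moving the chloro gives a 1.6-fold higher number from compound 1 to compound 4 (0.21 log units; within the scatter) and so also stays within the scatter, while 2-chlorophenyl in place of 1-benzothiophen-2-yl gives a 1.8-fold lower number from compound 2 to compound 4 (0.24 log units; within the scatter), leaving compound 4 not separable from compound 2, although compound 3 is. No evidence on hand accounts for these steps. Still open, as far as these compounds go, is whether a methoxy group, an amine or a carboxylic acid at this same place would stay within the scatter of compound 3.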